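The compounds below may be only part of what the source reports. "The series", "measured", "known", "first", "only" and "open" are said of these compounds alone.

In a functional assay on HeLa cells (Homo sapiens) for antiproliferative activity, read by MTT assay, with a stated time of 72 h (on this read-out higher numbers stand for weaker inhibition and lower numbers for stronger inhibition), the values so far are:

Compound 1 `COc1cccc(N2C(=O)COc3ccc(-c4cccc(NS(=O)(=O)c5ccc(F)cc5)c4)cc32)c1`: > 40000 nM, a limit of the assay
Compound 2 `O=C1COc2ccc(-c3cnc4ccccc4c3)cc2N1C1CCCCC1`: 19700 nM
Compound 3 `Cc1ccc(N2C(=O)COc3ccc(-c4cnc(Cl)c(NS(=O)(=O)c5ccc(F)cc5)c4)cc32)cc1`: 32300 nM
Compound 4 `O=C1COc2ccc(-c3cnc4ccccc4c3)cc2N1c1ccc(F)cc1`: not yet measured

Within the data shown here, compound 2 gives 19700 nM, one of only two true numbers in this small set. Compound 3 gives 32300 nM, which lies within the usual scatter of compound 2, so the two cannot be told apart in this assay. Compound 1 gives only a limit, not a number: > 40000 nM.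

Compound 4 differs from compound 2 in one place: 4-fluorophenyl in place of cyclohexyl on an amide-type nitrogen in a ring. Among the measured compounds shown here, no measured pair shows this change on its own, so there is no direct guide to its size. Compound 3 also carries a six-membered aromatic ring on that nitrogen, although it differs elsewhere as well, and compound 3 gives 32300 nM. Compound 1 also carries such a ring, and its result is the limit > 40000 nM.

On this slim evidence, no change beyond the scatter is expected in this assay, in either direction. The expected size of the change is a 1.1-fold lower number from compound 2 to compound 4 (0.04 log units; within the scatter). Compound 4 is estimated at 18000 nM, with an expected range from 6000 nM to 40000 nM.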

Compound 4, half-maximal inhibitory concentration: 38800 nM
Estimate against measurement, compound 4: 2.2-fold (0.33 log units) below; measured number inside the range.
By their numbers in this assay, from the lowest: compounds 2, 3 and 4 (each within the scatter of the next). At a limit, above all of these: compound 1.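

In this assay, among these compounds, this pair gives the first direct reading of a change on the amide-type nitrogen in a ring; compound 1 and compound 3 also carry an aromatic ring there, but they differ elsewhere as well, so neither could isolate that position. Exchanging cyclohexyl, a non-aromatic ring of carbon only, for 4-fluorophenyl, an aromatic ring with one added fluorine, gives a 2.0-fold higher number from compound 2 to compound 4 (0.29 log units; within the scatter), so on this core no real difference between the two groups can be claimed. Neither group brings strong inhibition here, and the read-out has a limit not far off: the limit of > 40000 nM in this assay, at which 1 of the 4 values shown sits.

The compounds shown leave open whether the type of ring or the fluorine counts for more, a question that a plain phenyl on the same nitrogen, set against both cyclohexyl and 4-fluorophenyl, would help to separate. Also open, from the compounds shown here alone, is how this position responds to groups of a different kind, such as a short chain ending in an amine or a carboxylic acid, and whether any of them would move the number beyond the scatter.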